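The source may hold more compounds than are shown below. What is called first, only, known or untested is meant among the compounds shown, and "the series" means these compounds.

Series notes, antiproliferative read-out.

Three analogues share one core and differ only in the ring at the end of the propoxy chain. In a functional assay on HepG2 cells (Homo sapiens) for antiproliferative activity, read by MTT assay, with a stated time of 72 h (a lower number here means a stronger inhibitor, a higher number a weaker inhibitor), compound 1 `COc1cc2c(Nc3ccc(C#N)cc3)ncnc2cc1OCCCN1CCCCC1` gives 20700 nM, which is the second highest of the three numbers. Compound 2 `COc1cc2c(Nc3ccc(C#N)cc3)ncnc2cc1OCCCN1CCC(O)CC1` gives 67900 nM in this assay, and compound 3 `COc1cc2c(Nc3ccc(C#N)cc3)ncnc2cc1OCCCN1CCC(c2ccccc2)CC1` gives 4610 nM. The steps among them are a 3.3-fold higher number from compound 1 to compound 2 (0.52 log units; beyond the scatter), a 4.5-fold lower number from compound 1 to compound 3 (0.65 log units; beyond the scatter) and a 15-fold lower number from compound 2 to compound 3 (1.17 log units; beyond the scatter); each of them alters a substituent on a saturated ring carbon while keeping the ring itself.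

Compound 4 `COc1cc2c(Nc3ccc(C#N)cc3)ncnc2cc1OCCCN1CCN(C)CC1` is not yet measured. Its change from compound 1 is 4-methylpiperazin-1-yl in place of piperidin-1-yl on a saturated chain carbon, three bonds along the chain from an oxygen on an aromatic ring.

Among the measured compounds shown here, none of the measured steps bears on this change directly: all three replace a hydrogen, a hydroxy or a phenyl on a ring carbon, whereas here the whole ring is exchanged. The nearest comparison is compound 1 itself, whose unsubstituted piperidinyl ring sits between the hydroxy and phenyl variants on the numbers. For the measured compounds named here, with no step of the same kind available, the expectation for compound 4 is a number close to that of compound 1, with a wide range on either side and no expected direction beyond the scatter; the expected step is a 1.0-fold lower number from compound 1 to compound 4 (0.01 log units; within the scatter). Compound 4 is estimated at 20000 nM, with a range from 6000 nM to 65000 nM.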

Compound 4, half-maximal inhibitory concentration: 13800 nM
Compound 4: the middle estimate sits 1.4-fold (0.16 log units) above what was measured; low and high end bracket the measured number.
By their numbers in this assay, from the lowest: compound 3; then compounds 4 and 1 (each within the scatter of the next); then compound 2.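

Compound 4 adds a change of the ring itself to a series that so far varied only a substituent on a saturated ring carbon, and in this assay the step is small: a 1.5-fold lower number from compound 1 to compound 4 (0.18 log units; within the scatter) lies within the scatter, so 4-methylpiperazin-1-yl and piperidin-1-yl cannot be told apart at the end of this propyl chain. The position therefore accepts a second ring nitrogen carrying a methyl with no readable change in the number, whereas the 4-phenylpiperidin-1-yl and 4-hydroxypiperidin-1-yl rings stay clearly apart from compound 4, with a 3.0-fold higher number from compound 3 to compound 4 (0.48 log units; beyond the scatter) on one side and a 4.9-fold lower number from compound 2 to compound 4 (0.69 log units; beyond the scatter) on the other. Nothing available accounts for any of these numbers, for the ring exchange or for the substituents on the ring.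

Still open, going by these compounds, is whether the ring nitrogen and its methyl each matter on their own, which a piperazin-1-yl or a morpholin-4-yl ring at the same place would help separate. Also open, on these data alone, is whether the lower number of compound 3 carries over to a 4-phenylpiperazin-1-yl ring, and how a shorter or longer chain would behave.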